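The compounds below may be only part of what the source reports. "The series", "measured", "known", "first", "only" and "open" are said of these compounds alone.

Measured so far in a functional assay on MCF7 cells (Homo sapiens) for inhibition, read by MTT assay, with a stated time of 72 h; a higher number here means a weaker inhibitor, a lower number a stronger inhibitor:
- compound 1 `Cc1cc(Nc2cc(-c3ccccc3)[nH]n2)n2nc(SCc3ccc(Cl)cc3)nc2n1` gives 8260 nM
- compound 2 `Cc1cc(Nc2cc(-c3ccccc3)[nH]n2)n2nc(SCc3cccc4ccccc34)nc2n1` gives 7560 nM

Compound 2 stands within the scatter of compound 1, and the two numbers give no ranking. Next in line is compound 3 `Cc1cc(Nc2cc(-c3ccccc3)[nH]n2)n2nc(SCc3csc4ccccc34)nc2n1`, with 1-benzothiophen-3-yl in place of naphthalen-1-yl on a saturated chain carbon bound to a sulfur and the rest of the structure unchanged. Among the compounds with values here, the only measured step at this place is a 1.1-fold lower number from compound 1 to compound 2 (0.04 log units; within the scatter) and it stays within the scatter, with naphthalen-1-yl taking the place of 4-chlorophenyl. Within the data shown here, one step is thin evidence, and no 1-benzothiophen-3-yl compound has a measured value yet. Among the measured compounds shown here, with that step as the only guide, no step beyond the scatter is expected in this assay and no direction is favoured. The estimated change is a 1.0-fold lower number from compound 2 to compound 3 (0.00 log units; within the scatter) and it is expected to stay within the scatter. For compound 3 the expected value is 7500 nM (estimated range 3700 nM to 15000 nM).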

Compound 3, half-maximal inhibitory concentration: 3470 nM
Estimate against measurement, compound 3: 2.2-fold (0.33 log units) above, and the stated range ends above it.
By their numbers in this assay, from the lowest: compound 3; then compounds 2 and 1 (each within the scatter of the next).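

In this assay, within the data shown here, the group on a saturated chain carbon bound to a sulfur now moves the number beyond the scatter for the first time: 1-benzothiophen-3-yl in place of naphthalen-1-yl gives (a 2.2-fold lower number from compound 2 to compound 3 (0.34 log units; beyond the scatter)), and 1-benzothiophen-3-yl in place of 4-chlorophenyl gives (a 2.4-fold lower number from compound 1 to compound 3 (0.38 log units; beyond the scatter)). Both steps are modest and similar in size, whereas naphthalen-1-yl and 4-chlorophenyl could not be told apart, so this place does respond to the choice of ring system, at least for these three groups. Nothing measured here bears on why the change to one five-membered aromatic ring with 1 hetero atom and one six-membered aromatic ring of carbon only goes with the lower number.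

Still open, from the compounds shown here alone, is whether benzofuran-3-yl or indol-3-yl, with oxygen or nitrogen in place of the ring sulfur, would follow 1-benzothiophen-3-yl at this place. Also open, going by these compounds, is how an amine or a carboxylic acid on the ring, or a longer chain from the sulfur to the ring, would read in this assay.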